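Tetrazolylthio acetohydrazones: nitro to fluoro on the aryl ring

The source may hold more compounds than are shown below. What is called first, only, known or untested is meant among the compounds shown, and "the series" means these compounds.

The series shares one core, a methyltetrazolylthio acetohydrazone carrying an aryl ring. Compound 1 `Cn1nnnc1SCC(=O)N/N=C/c1ccc([N+](=O)[O-])cc1` and compound 2 `Cn1nnnc1SCC(=O)N/N=C/c1ccc(F)cc1` differ by fluoro in place of nitro on an aromatic carbon; compound 3 `Cn1nnnc1SCC(=O)N/N=C/c1cccc([N+](=O)[O-])c1` and the unmeasured compound 4 `Cn1nnnc1SCC(=O)N/N=C/c1cccc(F)c1` differ by fluoro in place of nitro on an aromatic carbon. The two place lines are not identical, para to a large group in the first pair and meta to a large group in the second, so the two changes are the same kind of change rather than the same change. Compound 3 has the same atoms as compound 1, joined differently; the difference between the two cores is not broken down here.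

In an ADME assay on NIH3T3 cells (Mus musculus) for cytotoxicity, read by XTT assay, with a stated time of 24 h (on this read-out lower numbers stand for stronger inhibition and higher numbers for weaker inhibition), compound 1 gives 9300000 nM and compound 2 gives 10000000 nM, a step of a 1.1-fold higher number from compound 1 to compound 2 (0.03 log units; within the scatter). Compound 3 gives 2000000 nM in this assay, the lowest number of the three, with its steps to compound 1 and compound 2 both beyond the scatter.

For compound 4 the expectation rests on compound 1 and compound 2, whose step a 1.1-fold higher number from compound 1 to compound 2 (0.03 log units; within the scatter) lies within the scatter; the same kind of change is therefore expected to move compound 3 little, and compound 4 is expected to sit at 2300000 nM in this assay, with a range from 900000 nM to 6000000 nM. The step from compound 3 to compound 4 is thus estimated at a 1.2-fold higher number from compound 3 to compound 4 (0.06 log units; within the scatter).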

Compound 4, half-maximal inhibitory concentration: 6320000 nM
Compound 4: middle estimate off by 2.7-fold (0.44 log units), on the low side, outside the stated range (above it).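

In this assay, fluoro in place of nitro, meta to a large group, gives a 3.2-fold higher number from compound 3 to compound 4 (0.50 log units; beyond the scatter), a modest step but one beyond the scatter. Set beside the step for the same kind of change para to a large group, it shows that the size of this change does not carry over from one core to the other in this series: the same change on two cores in this assay, a 1.1-fold higher number (0.03 log units; within the scatter) from compound 1 to compound 2 and a 3.2-fold higher number (0.50 log units; beyond the scatter) from compound 3 to compound 4, 2.9-fold (0.47 log units) apart, beyond the scatter of two such steps

A step that stays within the scatter on the core of compound 1 is therefore no safe guide to the same kind of change on the core of compound 3, but two pairs give neither a reason for the gap nor a rule for any other core.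

Still open, as far as these compounds go, is whether other groups on the same aromatic carbon, such as an amine, a carboxylic acid or a methoxy group, would give a small step like the first pair or a larger one like the second. Also open, from the compounds shown here alone, is whether the gap between the two steps would hold for fluoro and nitro on other cores, or would appear in any other cell line or read-out.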